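This account rests on a few compounds, and the source may have more. Where it says the series, first, only, none or still open, it means among the compounds named here.

The series shares a common core carrying a carboxylic acid, with variation at the ring nitrogen and on the central benzene. Compound 1 `CCC(CC)n1c(-c2ccc(OCc3c(-c4c(Cl)cccc4Cl)noc3C(C)C)cc2F)nc2ccc(C(=O)O)cc21` is measured in an assay on HEK-293T cells for antagonist activity at vitamin D3 receptor (Homo sapiens), read by a luciferase reporter, with a stated time of 24 h (a lower number here means a stronger inhibitor, a higher number a weaker inhibitor), only as a limit, > 10000 nM, and sits at the limit of > 10000 nM in this assay, at which 1 of the 3 values shown sits. Compound 2 `CCC(CC)n1c(-c2ccc(OCc3c(-c4c(Cl)cccc4Cl)noc3C(C)C)cc2Cl)nc2ccc(C(=O)O)cc21` gives 1010 nM in this assay. Among the measured compounds shown here, the step of an at least 9.9-fold lower number from compound 1 to compound 2 (0.99 log units; beyond the scatter) is the single change for which two numbers exist. Compound 3 `CC(C)c1onc(-c2c(Cl)cccc2Cl)c1COc1ccc(-c2nc3ccc(C(=O)O)cc3n2C2CC2)cc1` gives 3200 nM in this assay, the highest of the two numbers and a higher value than compound 2, a gap that lies beyond the scatter.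

Compound 4 `CC(C)Cn1c(-c2ccc(OCc3c(-c4c(Cl)cccc4Cl)noc3C(C)C)cc2)nc2ccc(C(=O)O)cc21` differs from compound 3 by isobutyl in place of cyclopropyl on an aromatic nitrogen. No measured step touches the group on the ring nitrogen: the only step shown concerns a halogen on the central benzene, so nothing among the numbers tells how this assay answers the new isobutyl. The expectation is therefore a step of a 1.3-fold lower number from compound 3 to compound 4 (0.11 log units; within the scatter), lying within the scatter, with compound 3 as the anchor. Compound 4 is estimated to give 2500 nM in this assay, between 700 nM and 9000 nM.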

Compound 4, half-maximal inhibitory concentration: 1180 nM
Compound 4: middle estimate off by 2.1-fold (0.33 log units), on the high side; the range from low to high includes it.
By their numbers in this assay, from the lowest: compounds 2 and 4 (each within the scatter of the next); then compound 3. At a limit, above all of these: compound 1.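

In this assay, among the compounds shown here, the step of a 2.7-fold lower number from compound 3 to compound 4 (0.43 log units; beyond the scatter) is the first measured change on the aromatic nitrogen, and it lies beyond the scatter. It shows that this assay responds to the group at this position, and that isobutyl, with no ring, gives a lower number here than cyclopropyl, whereas the earlier step spoke only to a halogen on the central benzene. Nothing measured here accounts for the size or direction of this step.

The compounds shown leave open how this position would answer a longer chain such as n-hexyl, or a chain ending in an amine. As far as these compounds go, it also remains open whether the same change would give a similar step with a chloro or fluoro group on the central benzene.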